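Trimming the Amide of Compound 1: A Solubility Outlook

This account rests on a few compounds, and the source may have more. Where it says the series, first, only, none or still open, it means among the compounds named here.

Measured compounds:
compound 1, `CNC(=O)c1cc(C(=O)Nc2cnn(C)c2)cc2c1OC[C@H]2c1ccccc1`, in a physicochemical assay for solubility (a lower number here means a less soluble compound, a higher number a more soluble compound), gives >= 189 ug/mL
compound 2, `CNC(=O)c1cc(C(=O)N[C@H]2[C@@H]3COC[C@@H]32)cc2c1OC[C@H]2c1cccc2[nH]ccc12`, in this assay gives >= 171 ug/mL

Compound 1 gives a reading >= 189 ug/mL that is a limit of this assay, not a number. Compound 2 gives a reading >= 171 ug/mL that is likewise a limit. Going by the values given here, compound 1 thus stands at the upper bound of what this assay reports (the limit of >= 189 ug/mL in this assay, at which 1 of the 2 values shown sits), and compound 2 sits at a bound of its own (the limit of >= 171 ug/mL in this assay, at which 1 of the 2 values shown sits), so nothing orders the two against each other, and no step between measured compounds is available.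

Compound 3, `CNC(=O)c1cc(C(N)=O)cc2c1OC[C@H]2c1ccccc1`, has not been measured. It differs from compound 1 in one place: hydrogen in place of 1-methyl-1H-pyrazol-4-yl on an amide-type nitrogen. Nothing measured here shows what such a change does to solubility. Since compound 1 already sits at a limit (the limit of >= 189 ug/mL in this assay, at which 1 of the 2 values shown sits), the step that the limit leaves unreadable from compound 1 to compound 3 is expected to be no more than scatter, and the result is expected to come back as a limit once more. Compound 3 is estimated at 200 ug/mL, within 100 ug/mL to 400 ug/mL.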

Compound 3, solubility: >= 144 ug/mL
Compound 3 ended at the assay's limit; the forecaster's own chance of this, stated with the estimate: 70%; the middle value lies beyond the limit too.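

In this assay compound 3 gives >= 144 ug/mL, which is a limit of the assay and not a number. Going by these compounds alone, compound 1 also stands at a limit, and no step between compound 1 and compound 3 can be read. The compounds shown leave open whether hydrogen in place of 1-methyl-1H-pyrazol-4-yl on an amide-type nitrogen changes solubility at all.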